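Methyl on the core of compound 3: expected effect

The source may report more compounds than this note shows. Statements on the series, on what has been measured and on what is new or still open speak of the compounds shown alone.

Compound 3 `CC/C=C\C(=O)Nc1cc(Nc2nccc(-c3cn(C)c4ccccc34)n2)c(OC)cc1N(C)CCN(C)C` gives 3860 nM in a functional assay on NCI-H1975 cells (Homo sapiens) for antiproliferative activity, read by MTT assay, with a stated time of 72 h (a lower number here means a stronger inhibitor, a higher number a weaker inhibitor), the second highest of the three numbers. Compound 1 `C=C(Cl)C(=O)Nc1cc(Nc2nccc(-c3cn(C)c4ccccc34)n2)c(OC)cc1N(C)CCN(C)C` gives 1290 nM and compound 2 `C/C=C\C(=O)Nc1cc(Nc2nccc(-c3cn(C)c4ccccc34)n2)c(OC)cc1N(C)CCN(C)C` gives 4540 nM; the measured steps are a 3.5-fold higher number from compound 1 to compound 2 (0.55 log units; beyond the scatter), a 3.0-fold higher number from compound 1 to compound 3 (0.48 log units; beyond the scatter) and a 1.2-fold lower number from compound 2 to compound 3 (0.07 log units; within the scatter), all at the amide side chain. Compound 4 `CC/C=C\C(=O)Nc1cc(Nc2nc(C)cc(-c3cn(C)c4ccccc34)n2)c(OC)cc1N(C)CCN(C)C` differs from compound 3 by methyl in place of hydrogen on an aromatic carbon, next to the ring nitrogen, opposite the ring nitrogen. For the measured compounds named here, no measured step touches this aromatic carbon, so none bears directly on the change; the expectation is a step of a 1.0-fold higher number from compound 3 to compound 4 (0.02 log units; within the scatter), within the scatter. Compound 4 is estimated at 4000 nM in this assay, with a range from 1400 nM to 11000 nM.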

Compound 4, half-maximal inhibitory concentration: 1990 nM
Estimate against measurement, compound 4: 2.0-fold (0.30 log units) above; measured number inside the range.
By their numbers in this assay, from the lowest: compounds 1, 4, 3 and 2 (each within the scatter of the next, the first and the last beyond it).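

In this assay, for the compounds shown here, methyl in place of hydrogen on this aromatic carbon gives a 1.9-fold lower number from compound 3 to compound 4 (0.29 log units; within the scatter), the first measured step on the shared core rather than at the amide side chain. This position therefore carries a methyl with no step beyond the scatter, at least alongside the but-1-en-1-yl amide of compound 3 and compound 4. No available evidence bears on this result.

Going by these compounds, it remains open whether a larger group here, such as ethyl, methoxy or dimethylamino, would also stay within the scatter. Also open, on these data alone, is whether methyl at this position would give a similar step with the 1-chloroethenyl amide of compound 1.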